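Swapping fluoro for cyano on compound 3

A few compounds are considered here, and "the series" means these few. Any claim that something is new, unique, unknown or untested is made for them only; others in the source may bear on it.

Compound 1 `N#Cc1ccc(S(=O)(=O)N2C/C(=C\c3cccnc3)C(=O)/C(=C/c3ccccc3F)C2)cc1` gives > 20000 nM (a limit of the assay)
Compound 2 `O=C1/C(=C/c2ccncc2)CN(S(=O)(=O)c2ccccc2)C/C1=C\c1ccccc1F` gives 15900 nM
Compound 3 `O=C1/C(=C/c2ccncc2)CN(S(=O)(=O)c2ccc(F)cc2)C/C1=C\c1ccccc1F` gives 15600 nM

Among the measured compounds shown here, in an ADME assay on L02 cells (Homo sapiens) for cytotoxicity, read by MTT assay, with a stated time of 24 h (on this read-out higher numbers stand for weaker inhibition and lower numbers for stronger inhibition), compound 3 stands level with compound 2, and these two are the only true numbers so far. Compound 4 `N#Cc1ccc(S(=O)(=O)N2C/C(=C\c3ccncc3)C(=O)/C(=C/c3ccccc3F)C2)cc1` carries cyano in place of fluoro on an aromatic carbon. For the measured compounds named here, the one measured step put fluoro in place of hydrogen on an aromatic carbon, and it came to a 1.0-fold lower number from compound 2 to compound 3 (0.01 log units; within the scatter) and no more. Compound 1 also carries the 4-cyanophenyl group, and its > 20000 nM is a limit of the assay. A small step toward a higher number, no larger than the scatter, is therefore expected (a 1.2-fold higher number from compound 3 to compound 4 (0.06 log units; within the scatter)). For compound 4 the estimated value is 18000 nM (expected range 9000 nM to 35000 nM).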

Compound 4, half-maximal inhibitory concentration: > 20000 nM
Compound 4: only a limit was reported; the forecaster's own chance of this, stated with the estimate: 45%; middle value at least 1.1-fold (0.04 log units) away from the limit.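

In this assay, cyano in place of fluoro at this position gives an at least 1.2-fold higher number from compound 3 to compound 4 (0.10 log units; that floor lies within the scatter), and cyano in place of hydrogen gives an at least 1.2-fold higher number from compound 2 to compound 4 (0.09 log units; that floor lies within the scatter). Neither step shows a lower number, though each floor lies within the scatter. Compound 4 and compound 1 each report only a limit, so the true size of these steps and the step between those two compounds cannot be read: the limit of > 20000 nM in this assay, at which 2 of the 4 values shown sit.

From the compounds shown here alone, whether an amine or a carboxylic acid at this position would move the number beyond the scatter stays open.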